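Amide aryl swap: dichlorophenyl gives way to fluoropyridinyl

The source may report more compounds than this note shows. Statements on the series, on what has been measured and on what is new or still open speak of the compounds shown alone.

Three amides on a shared core have been measured in an assay on isolated protein for inhibition of histone deacetylase 4 (Homo sapiens), with a stated time of 1 h; on this read-out higher numbers stand for weaker inhibition and lower numbers for stronger inhibition. Compound 1 `O=C(COc1ccc2cc(/C=C3/SC(=O)NC3=O)ccc2c1)Nc1ccc(Br)cc1` gives 2900 nM. Compound 2 `Cc1cccc(NC(=O)COc2ccc3cc(/C=C4/SC(=O)NC4=O)ccc3c2)n1` gives 1100 nM, the lowest number of the three. Compound 3 `O=C(COc1ccc2cc(/C=C3/SC(=O)NC3=O)ccc2c1)Nc1ccc(Cl)c(Cl)c1` gives 5500 nM, the highest of the three numbers; its nearest neighbour is compound 1, with a 1.9-fold higher number from compound 1 to compound 3 (0.28 log units; within the scatter), while the step of a 5.0-fold higher number from compound 2 to compound 3 (0.70 log units; beyond the scatter) is the widest in the set.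

The next compound, compound 4 `O=C(COc1ccc2cc(/C=C3/SC(=O)NC3=O)ccc2c1)Nc1cccc(F)n1`, carries the change (6-fluoropyridin-2-yl in place of 3,4-dichlorophenyl on an amide-type nitrogen). The step that bears on this is a 5.0-fold higher number from compound 2 to compound 3 (0.70 log units; beyond the scatter): read in reverse, a pyridin-2-yl entering in place of the 3,4-dichlorophenyl points to a lower number. The step of a 2.6-fold lower number from compound 1 to compound 2 (0.42 log units; beyond the scatter) points the same way, though with a different ring leaving. Nothing measured tells how a fluorine on that ring compares with a methyl, so the expectation rests on the ring type alone.

Compound 4 is therefore expected to show a modest downward step, a 3.9-fold lower number from compound 3 to compound 4 (0.59 log units; beyond the scatter), because compound 2 with its pyridin-2-yl gives 1100 nM. The estimate for compound 4 in this assay is 1400 nM, with a range from 500 nM to 4000 nM.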

Compound 4, half-maximal inhibitory concentration: 840 nM
Estimate against measurement, compound 4: 1.7-fold (0.22 log units) above, within the range that was stated.
By their numbers in this assay, from the lowest: compounds 4 and 2 (each within the scatter of the next); then compounds 1 and 3 (each within the scatter of the next).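

On the amide-type nitrogen in this assay, 6-fluoropyridin-2-yl in place of 3,4-dichlorophenyl gives a clear drop (a 6.5-fold lower number from compound 3 to compound 4 (0.82 log units; beyond the scatter)), and in place of 4-bromophenyl it gives a similar one (a 3.5-fold lower number from compound 1 to compound 4 (0.54 log units; beyond the scatter)), so the lower numbers first seen with 6-methylpyridin-2-yl now hold for a second pyridinyl amide. Fluoro in place of methyl on an aromatic carbon leaves the number within the scatter (a 1.3-fold lower number from compound 2 to compound 4 (0.12 log units; within the scatter)), so these two groups cannot be told apart on this read-out. No supporting data bear on why these rings give lower numbers.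

The compounds shown leave open whether the lower numbers go with the ring nitrogen or with the group on that ring. An unsubstituted pyridin-2-yl, or a pyridin-2-yl carrying an amine or a carboxylic acid in place of the fluoro, would bear on that question.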